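The compounds below may be only part of what the source reports. "The series", "measured", "known", "first", "only" and "open" are said of these compounds alone.

Two compounds of this series carry measurements. Compound 1 `N#Cc1cccc(-n2cc(COc3cccc(NC(=O)Nc4ccc(Cl)c(C(F)(F)F)c4)c3)nn2)c1` gives 2760 nM in a functional assay on HepG2 cells (Homo sapiens) for inhibition, read by MTT assay, with a stated time of 72 h (on this read-out higher numbers stand for weaker inhibition and lower numbers for stronger inhibition), and compound 2 `O=C(Nc1cccc(OCc2cn(-c3ccc(F)cc3)nn2)c1)Nc1ccc(Cl)c(C(F)(F)F)c1` gives 1350 nM. Among the measured compounds shown here, compound 2 thus holds the lowest of the two numbers; the only neighbour is compound 1, and the single one-place step between them, a 2.0-fold lower number from compound 1 to compound 2 (0.31 log units; beyond the scatter), came from 4-fluorophenyl in place of 3-cyanophenyl on the aromatic nitrogen of the shared core.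

Compound 3 `O=C(Nc1cccc(OCc2cn(-c3cccc(Cl)c3)nn2)c1)Nc1ccc(Cl)c(C(F)(F)F)c1` is the next point at that same place: 3-chlorophenyl in place of 4-fluorophenyl on an aromatic nitrogen. For the measured compounds named here, the one step that bears on it is a 2.0-fold lower number from compound 1 to compound 2 (0.31 log units; beyond the scatter), a modest move that shows the aryl group on the ring nitrogen can shift the read-out, but only by a small amount. Compound 1, which also carries a 3-substituted phenyl there, sits at the higher end of the two numbers. Going by the values given here, with one step of that size as the only guide, the expectation for compound 3 is a small change from compound 2, a 1.3-fold higher number from compound 2 to compound 3 (0.12 log units; within the scatter), with no firm direction. The estimate for compound 3 in this assay is therefore 1800 nM, within a range of 700 nM to 4500 nM.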

Compound 3, half-maximal inhibitory concentration: 2020 nM
Compound 3: the middle estimate sits 1.1-fold (0.05 log units) below what was measured, and the stated range covers the measured number.
By their numbers in this assay, from the lowest: compounds 2, 3 and 1 (each within the scatter of the next, the first and the last beyond it).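

In this assay, 3-chlorophenyl in place of 4-fluorophenyl on the aromatic nitrogen gives a step within the scatter (a 1.5-fold higher number from compound 2 to compound 3 (0.18 log units; within the scatter)), and chloro in place of cyano on an aromatic carbon also gives a step within the scatter (a 1.4-fold lower number from compound 1 to compound 3 (0.14 log units; within the scatter)). Compound 3 therefore cannot be separated from either compound 1 or compound 2, although those two are set apart beyond the scatter (a 2.0-fold lower number from compound 1 to compound 2 (0.31 log units; beyond the scatter)), and the three aryl groups shown on this nitrogen span only a narrow band of values; the step from 4-fluorophenyl to 3-chlorophenyl also changes both the halogen and its place on the phenyl ring, so these two changes cannot be read apart. No measurement available here bears on what lies behind these steps.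

As far as these compounds go, all three compounds carry a halogen- or nitrile-bearing phenyl on the ring nitrogen, so the read-out in this assay remains open for an unsubstituted phenyl, a cyclohexyl, or a phenyl bearing an amine or a carboxylic acid at this place. A 4-chlorophenyl group would hold the halogen constant and vary only its place on the ring, and it lies outside the compounds shown.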